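The source may hold more compounds than are shown below. What is called first, only, known or untested is meant among the compounds shown, and "the series" means these compounds.

Measured compounds:
compound 1, `O=C(NCc1ccc(CNS(=O)(=O)c2ccccc2)cc1)c1ccccc1`, 1 nM
compound 2, `O=C(NCc1ccc(CNS(=O)(=O)c2ccccc2)cc1)c1ccc(Cl)cc1`, 100 nM

For the measured compounds named here, compound 2 stands at the higher of the two numbers in an assay on MDA-MB-231 cells for binding affinity to C-X-C chemokine receptor type 4 (Homo sapiens), read by immunofluorescence and microscopy, with stated times of 10 min and 30 min; on this read-out lower numbers stand for an effect already at smaller amounts and higher numbers for an effect only at larger amounts of compound; the only neighbour is compound 1, and the step from it is a 100-fold higher number from compound 1 to compound 2 (2.00 log units; beyond the scatter). Compound 3, `O=C(NCc1ccc(CNS(=O)(=O)c2ccccc2)cc1)c1ccc(F)cc1`, is not yet measured. It differs from compound 2 in one place: fluoro in place of chloro on an aromatic carbon. Going by the values given here, no measured step makes this exact change. Among the compounds with values here, the one step that bears on it, a 100-fold higher number from compound 1 to compound 2 (2.00 log units; beyond the scatter), shows that a chloro at this aromatic carbon goes with a far higher number than hydrogen there. Since fluoro is a halogen like chloro but sits in the same place where hydrogen gave the low number of compound 1, compound 3 is expected to land between the two, with a step of a 10-fold lower number from compound 2 to compound 3 (1.00 log units; beyond the scatter). Within the data shown here, the estimate for compound 3 in this assay is 10 nM, in a range from 1 nM to 100 nM, broad because only the step of a 100-fold higher number from compound 1 to compound 2 (2.00 log units; beyond the scatter) informs it.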

Compound 3, effective concentration (reported as EC, without a stated level of effect): 100 nM
Compound 3: the middle estimate sits 10-fold (1.00 log units) below what was measured, and the stated range covers the measured number.
By their numbers in this assay, from the lowest: compound 1; then compounds 2 and 3 (each within the scatter of the next).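

In this assay, exchanging chloro for fluoro at this aromatic carbon, para to a large group, gives no change at the digits printed from compound 2 to compound 3 (within the scatter), so the read-out does not separate these two halogens here. Fluoro in place of hydrogen gives a 100-fold higher number from compound 1 to compound 3 (2.00 log units; beyond the scatter), which shows that the large step first seen with chloro is not particular to chloro, and among the compounds shown only the hydrogen of compound 1 goes with the low number. Nothing measured here speaks to the reason for this result.

On these data alone, it remains open whether other groups at this carbon, such as a methoxy group, an amine or a carboxylic acid, would stay level with compound 2 or come closer to compound 1. Also open, as far as these compounds go, is whether fluoro at another aromatic carbon of the shared core would give a step of the same size.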